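This account rests on a few compounds, and the source may have more. Where it says the series, first, only, none or still open, it means among the compounds named here.

Compound 1 `COc1cccc(/C=C2/C(C)=C(CC(=O)O)c3cc(F)ccc32)c1`: 300000 nM
Compound 2 `CC1=C(CC(=O)O)c2cc(F)ccc2/C1=C\c1cccs1`: 80000 nM
Compound 3 `CC1=C(CC(=O)O)c2cc(F)ccc2/C1=C\c1ccc(CO)o1`: 130000 nM; 120000 nM (2 entries)

In a functional assay on MDCK cells (Canis lupus familiaris) for antiproliferative activity (a higher number here means a weaker inhibitor, a lower number a stronger inhibitor), compound 1 gives the highest of the two single numbers; the nearest is compound 2, reached by a 3.8-fold lower number from compound 1 to compound 2 (0.57 log units; beyond the scatter) with thiophen-2-yl in place of 3-methoxyphenyl on a double-bonded chain carbon bound to a double-bonded ring carbon. Compound 3 has several entries, (the several entries of compound 3 in this assay, 130000 nM; 120000 nM (2 entries)), and these also lie under the number for compound 1. Compound 4 `CC1=C(CC(=O)O)c2cc(F)ccc2/C1=C\c1ccoc1` is not yet measured; it differs from compound 1 by furan-3-yl in place of 3-methoxyphenyl on a double-bonded chain carbon bound to a double-bonded ring carbon. Among the measured compounds shown here, the one measured step that bears on this change is a 3.8-fold lower number from compound 1 to compound 2 (0.57 log units; beyond the scatter), a modest fall when a five-membered aromatic ring with one hetero atom took the place of 3-methoxyphenyl; the entries of compound 3 point the same way. A fall of comparable size is therefore expected in this assay, beyond the scatter. Compound 4 is estimated at 100000 nM, with a range from 40000 nM to 250000 nM. That estimate means an expected 3.0-fold lower number from compound 1 to compound 4 (0.48 log units; beyond the scatter), toward a lower number.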

Compound 4, half-maximal inhibitory concentration: 50000 nM
Compound 4: the middle estimate sits 2.0-fold (0.30 log units) above what was measured; low and high end bracket the measured number.
By their numbers in this assay, from the lowest: compounds 4 and 2 (each within the scatter of the next); then compound 1.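

In this assay, furan-3-yl in place of 3-methoxyphenyl on a double-bonded chain carbon bound to a double-bonded ring carbon gives a 6.0-fold lower number from compound 1 to compound 4 (0.78 log units; beyond the scatter), so the fall seen with thiophen-2-yl is not confined to that one ring. The two five-membered rings are not separated here: a 1.6-fold lower number from compound 2 to compound 4 (0.20 log units; within the scatter) gives no ranking of furan-3-yl against thiophen-2-yl. Compound 3, the remaining five-membered ring compound, also lies under compound 1: the several entries of compound 3 in this assay, 130000 nM; 120000 nM (2 entries)

Compound 1 alone carries a six-membered ring, so the compounds shown leave open whether the fall follows the smaller ring or the absence of the methoxy group, which a plain phenyl would separate. Also open, on these data alone, is how an amine on the furan-3-yl ring would read in this assay.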